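A few compounds are considered here, and "the series" means these few. Any claim that something is new, unique, unknown or untested is made for them only; others in the source may bear on it.

Measured compounds in an assay on isolated protein for inhibition of Rho-associated protein kinase 1 (Homo sapiens), tested at 30 uM; on this read-out higher numbers stand for more inhibition at the one concentration tested (going by the name of the read-out) and lower numbers for less inhibition:
- compound 1 `Cn1cnc2c(SCc3ccccc3)ncnc21`: compound 1 gives 1%
- compound 2 `Cn1cnc2c(SCc3ccc(F)cc3)ncnc21`: compound 2 gives 6%
- compound 3 `Cn1cnc2c(-c3ccccc3)ncnc21`: compound 3 gives 8%

Compound 1 and compound 2 differ in one place, (fluoro in place of hydrogen on an aromatic carbon); the step in this assay is a number 5 percentage points higher from compound 1 to compound 2 (within the scatter), so the three numbers sit together in the scatter. The difference between the core of compound 1 and the core of compound 3 is not broken down here.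

Compound 4 `Cn1cnc2c(-c3ccc(F)cc3)ncnc21` has not yet been measured. It stands to compound 3 as compound 2 stands to compound 1: fluoro in place of hydrogen on an aromatic carbon, the same change at the same kind of place. With the measured step resting at a number 5 percentage points higher from compound 1 to compound 2 (within the scatter), the expected step in this assay is a number 2 percentage points higher from compound 3 to compound 4 (within the scatter). Compound 4 is therefore estimated at 10% in this assay, with the likely range from 0% to 22%.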

Compound 4, a percentage reported as inhibition, at one concentration (the size of the read-out at that concentration, not a potency): 10%
Compound 4: middle estimate and measured number agree at the digits printed; the range from low to high includes it.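

In this assay, fluoro in place of hydrogen on an aromatic carbon gives a number 2 percentage points higher from compound 3 to compound 4 (within the scatter). Set beside the earlier step, the change shows no difference between the two cores that stands clear of the scatter: the same change on two cores in this assay, a number 5 percentage points higher (within the scatter) from compound 1 to compound 2 and a number 2 percentage points higher (within the scatter) from compound 3 to compound 4, 3 percentage points apart, within the scatter of two such steps

Among these compounds, this shows only that the step stays within the scatter on both cores; it does not show that fluoro changes inhibition at all, nor that a larger effect would carry from one core to the other.

As far as these compounds go, whether an amine, a carboxylic acid or a longer chain in place of the fluoro would give a step beyond the scatter remains open. So does whether such a step would hold on both cores.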